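The source may report more compounds than this note shows. Statements on the series, on what has been measured and on what is new or still open speak of the compounds shown alone.

The three compounds measured in an assay on HEK293 cells for displacement of a labelled ligand from NPC1-like intracellular cholesterol transporter 1 (Homo sapiens) (on this read-out higher numbers stand for weaker inhibition and lower numbers for stronger inhibition), share one core and differ only in the amide attached to the chain carbon beside the core. Compound 1 `CC(C)(C)OC(=O)NCCNC(=O)CN1CN(c2ccccc2)C2(CCN(C(=O)c3ccc(C4CCCCC4)cc3)CC2)C1=O` gives 5500 nM. Compound 2 `O=C(CN1CN(c2ccccc2)C2(CCN(C(=O)c3ccc(C4CCCCC4)cc3)CC2)C1=O)N1CCCCC1` gives 1100 nM. Compound 3 `CC1CCCN(C(=O)CN2CN(c3ccccc3)C3(CCN(C(=O)c4ccc(C5CCCCC5)cc4)CC3)C2=O)C1` gives 3600 nM, which places compound 3 second highest of the three; its nearest neighbour is compound 1, and the gap between them lies within the usual scatter, while compound 2 sits further off, with a 3.3-fold higher number from compound 2 to compound 3 (0.51 log units; beyond the scatter).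

Compound 4 `O=C(CN1CN(c2ccccc2)C2(CCN(C(=O)c3ccc(C4CCCCC4)cc3)CC2)C1=O)NCCO` carries (2-hydroxyethyl)amino in place of 3-methylpiperidin-1-yl on a carbonyl carbon. Going by the values given here, two measured steps bear on this change. The exchange of the acyclic carbamate-bearing amine of compound 1 for the ring amine of compound 3 gave a 1.5-fold lower number from compound 1 to compound 3 (0.18 log units; within the scatter), and the related exchange toward the unsubstituted ring gave a 5.0-fold lower number from compound 1 to compound 2 (0.70 log units; beyond the scatter). Compound 4 returns to an acyclic amine, and of the measured compounds only compound 1 resembles it in that respect.

On this basis compound 4 is expected to land close to compound 3 and compound 1, with an expected step of a 1.4-fold higher number from compound 3 to compound 4 (0.14 log units; within the scatter) in this assay, not clearly beyond the scatter. The estimate for compound 4 is therefore 5000 nM, with a range from 2000 nM to 12000 nM.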

Compound 4, half-maximal inhibitory concentration: 2000 nM
Beside the measured number, compound 4's estimate is 2.5-fold (0.40 log units) above it; the range from low to high includes it.
By their numbers in this assay, from the lowest: compounds 2, 4, 3 and 1 (each within the scatter of the next, the first and the last beyond it).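

In this assay, the acyclic (2-hydroxyethyl)amino group on the carbonyl carbon cannot be told apart from either ring amine, with a 1.8-fold lower number from compound 3 to compound 4 (0.26 log units; within the scatter) and a 1.8-fold higher number from compound 2 to compound 4 (0.26 log units; within the scatter). Before this result, the only acyclic amine at this position was the one in compound 1, so a ring amine could have seemed to be what separated compound 2 from compound 1; compound 4 shows that an acyclic amine can also stand within the scatter of compound 2. Hydroxy in place of (tert-butoxycarbonyl)amino on the saturated chain carbon gives a 2.8-fold lower number from compound 1 to compound 4 (0.44 log units; beyond the scatter), so the group carried on the chain can move the number even when the amide stays acyclic. Nothing shown here gives a measured reason for these differences.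

On these data alone, whether an amine or a carboxylic acid in place of the hydroxy, or a longer chain between the amide nitrogen and the hydroxy, would hold the number or move it remains open. So does the contribution of the hydroxy itself, which an ethylamino group on the same carbonyl carbon would address.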